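A few compounds are considered here, and "the series" means these few. Any claim that something is new, unique, unknown or untested is made for them only; others in the source may bear on it.

Three compounds share one core and differ only in the group on the aromatic ring. In a functional assay on RAW264.7 cells (Mus musculus) for inhibition, with a stated time of 30 min (a lower number here means a stronger inhibitor, a higher number a weaker inhibitor), compound 1 `C=C1C(=O)OC[C@H]1CCOC(=O)Nc1ccc(C(C)C)cc1` gives 340 nM, compound 2 `C=C1C(=O)OC[C@H]1CCOC(=O)Nc1ccc(I)cc1` gives 490 nM, and compound 3 `C=C1C(=O)OC[C@H]1CCOC(=O)Nc1ccc(Cl)cc1` gives 390 nM. Compound 3 thus holds the second highest of the three numbers as they stand, though every pair lies within the scatter: a 1.1-fold higher number from compound 1 to compound 3 (0.06 log units; within the scatter), a 1.4-fold higher number from compound 1 to compound 2 (0.16 log units; within the scatter), and a 1.3-fold lower number from compound 2 to compound 3 (0.10 log units; within the scatter). Compound 4 `C=C1C(=O)OC[C@H]1CCOC(=O)Nc1ccc(CC)cc1` has not been measured; it differs from compound 3 by ethyl in place of chloro on an aromatic carbon. The closest guide, the step where chloro took the place of isopropyl, a 1.1-fold higher number from compound 1 to compound 3 (0.06 log units; within the scatter), stayed within the scatter, so no step beyond the scatter is expected in this assay here either. Compound 4 is therefore estimated at 360 nM, with a range of 180 nM to 720 nM, meaning an expected 1.1-fold lower number from compound 3 to compound 4 (0.03 log units; within the scatter).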

Compound 4, half-maximal inhibitory concentration: 840 nM
Compound 4: middle estimate off by 2.3-fold (0.37 log units), on the low side; the measured number lies above the stated range.
By their numbers in this assay, from the lowest: compounds 1, 3, 2 and 4 (each within the scatter of the next, the first and the last beyond it).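

Among these compounds, at this position the group matters more than the first three compounds suggested: ethyl in place of chloro (a 2.2-fold higher number from compound 3 to compound 4 (0.33 log units; beyond the scatter)) and hydrogen in place of one methyl of the isopropyl group (a 2.5-fold higher number from compound 1 to compound 4 (0.39 log units; beyond the scatter)) both move the number beyond the scatter in this assay, which no step among those three did. Ethyl in place of iodo (a 1.7-fold higher number from compound 2 to compound 4 (0.23 log units; within the scatter)) stays within the scatter, so compound 4 does not separate from every earlier compound. The data shown offer no measured explanation for this result. Open, on these data alone, is how a methyl group, a longer chain such as propyl, or an amine would behave at this position.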